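This account rests on a few compounds, and the source may have more. Where it says the series, first, only, none or still open, it means among the compounds named here.

In a functional assay on B16 cells (Mus musculus) for cytotoxicity (on this read-out higher numbers stand for weaker inhibition and lower numbers for stronger inhibition), compound 1 (`C=C1CC[C@H]2C(C)(C)CCC[C@]2(C)[C@H]1CC(O)c1ccoc1`) gives 47.2 ug/mL, while compound 2 (`CC(=O)O[C@]1(C)CC[C@H]2C(C)(C)CCC[C@]2(C)[C@H]1C/C=C1/CCOC1=O`) gives 11.3 ug/mL, the lower of the two numbers by a margin beyond the usual scatter. Compound 3 (`CC(=O)O[C@]1(C)CC[C@H]2C(C)(C)CCC[C@]2(C)[C@H]1CC=O`) has not yet been measured in this assay. It differs from compound 2 by a group of 2 heavy atoms (1 carbon, 1 oxygen; no ring) in place of a group of 7 heavy atoms (5 carbon, 2 oxygen; one five-membered non-aromatic ring with 1 hetero atom), on a saturated chain carbon bound to a saturated ring carbon, so formyl is what enters. Among the measured compounds shown here, no measured pair shows this change, which leaves the expectation loose: a modest move towards a higher number, near the edge of the scatter. The expected change is a 1.9-fold higher number from compound 2 to compound 3 (0.29 log units; within the scatter). Compound 3 is estimated at 22 ug/mL, with an expected range of 8 ug/mL to 60 ug/mL.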

Compound 3, half-maximal inhibitory concentration: 31.9 ug/mL
Estimate against measurement, compound 3: 1.5-fold (0.16 log units) below; the range from low to high includes it.
By their numbers in this assay, from the lowest: compound 2; then compounds 3 and 1 (each within the scatter of the next).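

In this assay, putting formyl in place of the group with the five-membered non-aromatic ring, on a saturated chain carbon bound to a saturated ring carbon, brings a 2.8-fold higher number from compound 2 to compound 3 (0.45 log units; beyond the scatter) as the first step read at this place. The larger ring-bearing group therefore goes with the lower number, while the formyl compound still gives a measurable value. Nothing available explains this step.

The compounds shown leave open whether the ring or the chain carbons that carry it matter more. A carboxylic acid or a primary amine at this place would help to separate these possibilities.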